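The source may report more compounds than this note shows. Statements on the series, on what has been measured and on what is new or still open speak of the compounds shown alone.

Measured so far in an ADME assay on BJ cells (Homo sapiens) for antiproliferative activity, with a stated time of 72 h; a lower number here means that less compound is needed, a higher number that more compound is needed for the effect:
Compound 1 `COc1ccc(-c2cc(=O)c3c(OC)cc(OC)cc3[nH]2)cc1`: > 62000 nM, a limit of the assay, not a number.
Compound 2 `COc1ccc(-c2cc(=O)c3c(OC)cc(OC)cc3n2S(=O)(=O)c2cc(F)c(F)c(F)c2)cc1`: > 65500 nM, also a limit.

Compound 2 therefore stands only at a limit (the limit of > 65500 nM in this assay, at which 1 of the 2 values shown sits). Compound 1 likewise sits at a limit (the limit of > 62000 nM in this assay, at which 1 of the 2 values shown sits). Neither gives a number to compare. Compound 3 `COc1ccc(-c2cc(=O)c3c(OC)cc(OC)cc3n2S(=O)(=O)c2ccc(OC)cc2)cc1` differs from compound 2 by 4-methoxyphenyl in place of 3,4,5-trifluorophenyl on a sulfonyl sulfur. Going by the values given here, no measured step covers a change of this kind. With both measured compounds at limits, no shift beyond the scatter is expected in this assay, and compound 3 is likely to return a limit as well. Compound 3 is estimated at 65000 nM (range 20000 nM to 200000 nM), so the expected step of a number no higher from compound 2 to compound 3 (the limit leaves the size open) is essentially none.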

Compound 3, half-maximal effective concentration: > 82700 nM
Compound 3 ended at the assay's limit; the forecaster's own chance of this, stated with the estimate: 85%; middle value at least 1.2-fold (0.10 log units) from the limit.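

Going by these compounds alone, compound 1, compound 2 and compound 3 all stand at limits in this assay, and no step among them can be read. The compounds shown leave open whether any group on the sulfonyl sulfur would give a measurable value in this assay.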